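Replacing the aryl group of compound 2 with 3-hydroxyphenyl

A few compounds are considered here, and "the series" means these few. Any claim that something is new, unique, unknown or untested is made for them only; others in the source may bear on it.

Among the compounds with values here, in a functional assay on HepG2 cells (Homo sapiens) for cytotoxicity, read by spectrophotometry, with a stated time of 72 h (a higher number here means a weaker inhibitor, a lower number a stronger inhibitor), compound 2 `COc1ccc(-c2cccc(=O)n2-c2cc(OC)c(OC)c(OC)c2)cc1C` gives 129 nM, the lower of the two numbers measured so far. Compound 1 `COc1cc(-n2c(-c3ccncc3)cccc2=O)cc(OC)c1OC` gives 1780 nM on the same core.

The next change leads to compound 3 `COc1cc(-n2c(-c3cccc(O)c3)cccc2=O)cc(OC)c1OC`: 3-hydroxyphenyl in place of 4-methoxy-3-methylphenyl on an aromatic carbon, next to the ring nitrogen (3-hydroxyphenyl in place of 4-methoxy-3-methylphenyl on an aromatic carbon). Both groups have one six-membered aromatic ring of carbon only.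

A single measured step bears on this change: a 14-fold lower number from compound 1 to compound 2 (1.14 log units; beyond the scatter), a large step that came with 4-methoxy-3-methylphenyl in place of pyridin-4-yl. It shows that the group on this carbon can shift the number in this assay well beyond the scatter. Within the data shown here, no measured compound carries 3-hydroxyphenyl, so the direction rests on thin evidence. Among the measured compounds shown here, compound 2 gives the only low number so far at 129 nM, and losing its group is expected to raise the number, though by less than the step above. The expected change is a 3.5-fold higher number from compound 2 to compound 3 (0.54 log units; beyond the scatter). For compound 3 the estimate is 450 nM, with an expected range of 100 nM to 2000 nM.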

Compound 3, half-maximal inhibitory concentration: 34 nM
Compound 3: the middle estimate sits 13-fold (1.12 log units) above what was measured; the whole stated range lies above it.
By their numbers in this assay, from the lowest: compound 3; then compound 2; then compound 1.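

Working notes on the group on the aromatic carbon next to the ring nitrogen: in this assay, 3-hydroxyphenyl gives a 3.8-fold lower number from compound 2 to compound 3 (0.58 log units; beyond the scatter), so the low numbers at this position do not depend on the 4-methoxy-3-methylphenyl group, and a smaller group with 1 hydrogen-bond donor is tolerated here. Against pyridin-4-yl the same change gives a 52-fold lower number from compound 1 to compound 3 (1.72 log units; beyond the scatter), and among these three compounds both groups with an aromatic ring of carbon only sit lower than pyridin-4-yl, with no compound going against that order. No measurement is available that explains the difference between these groups.

The change from compound 2 to compound 3 removes the methoxy and the methyl and adds the hydroxyl in a single step, so the share of each in the lower number remains unresolved. Whether the hydroxyl itself matters also remains open, and the compounds shown do not tell how an amine or a carboxylic acid in its place on the phenyl ring would read in this assay.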